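Aminofluoropyridinyl in Place of Difluorophenyl on the Shared Core

The source may report more compounds than this note shows. Statements on the series, on what has been measured and on what is new or still open speak of the compounds shown alone.

Three compounds share a core carrying a carboxymethyl group and have been tested in an in vitro assay on HEK385-7 cells for displacement of a labelled ligand from prostaglandin D2 receptor 2 (Homo sapiens); a higher number here means a weaker inhibitor, a lower number a stronger inhibitor. Compound 1 `O=C(O)Cc1sc(CSc2ccccc2)nc1-c1ccc(Cl)cc1` gives 250 nM. Compound 2 `O=C(O)Cc1sc(Cc2ccccc2-c2ccccc2)nc1-c1ccc(Cl)cc1` gives 41 nM. Compound 3 `O=C(O)Cc1sc(C(c2ccc(F)cc2)c2ccc(F)cc2)nc1-c1cc(F)cc(F)c1` gives 35 nM, the lowest of the three numbers; its gap to compound 2 lies within the scatter, so the two cannot be ordered, while its gap to compound 1 lies beyond it.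

Compound 4 `Nc1cc(-c2nc(C(c3ccc(F)cc3)c3ccc(F)cc3)sc2CC(=O)O)cc(F)n1` has not yet been measured in this assay. It differs from compound 3 in one place: 2-amino-6-fluoropyridin-4-yl in place of 3,5-difluorophenyl on an aromatic carbon. Among the compounds with values here, no measured pair shows this exchange, so there is no step to lean on. The carboxymethyl group and the group on the other ring atom are unchanged. On that basis the account expects a step from compound 3 to compound 4 of no change at the digits printed from compound 3 to compound 4 (within the scatter), that is, no change beyond the scatter. Compound 4 is therefore estimated at 35 nM, with a range from 10 nM to 120 nM.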

Compound 4, half-maximal inhibitory concentration: 220 nM
Beside the measured number, compound 4's estimate is 6.3-fold (0.80 log units) below it; measured number outside the range, above it.
By their numbers in this assay, from the lowest: compounds 3 and 2 (each within the scatter of the next); then compounds 4 and 1 (each within the scatter of the next).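

In this assay, placing 2-amino-6-fluoropyridin-4-yl instead of 3,5-difluorophenyl on the aromatic carbon next to the ring nitrogen gives a 6.3-fold higher number from compound 3 to compound 4 (0.80 log units; beyond the scatter), so this position does not tolerate every group of similar size, although both groups hold 8 heavy atoms. The entering group carries 1 hydrogen-bond donor and 2 hydrogen-bond acceptors where the leaving group has none, but this single exchange alters several features at once and cannot separate them. Nothing measured here explains the step.

The compounds shown leave open which part of the entering group accounts for the step, since neither 2-fluoropyridin-4-yl without the amine nor 2-aminopyridin-4-yl without the fluorine appears among them. Also open, from the compounds shown here alone, is whether the same exchange would give a similar step with a different large group on the shared core.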